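From Pyrrole to Imidazole: A Solubility Step

The source may report more compounds than this note shows. Statements on the series, on what has been measured and on what is new or still open speak of the compounds shown alone.

Compound 1 `O=C(O)c1ccc(-c2cscn2)cc1O`: 8700 ug/mL
Compound 2 `O=C(O)c1cc(-n2ccnc2)ccc1O`: 2000 ug/mL
Compound 3 `O=C(O)c1cc(-n2cccc2)ccc1O`: 8600 ug/mL

In a physicochemical assay for solubility, in phosphate buffer, at pH 7 (a higher number here means a more soluble compound, a lower number a less soluble compound), compound 3 gives 8600 ug/mL, the second highest of the three numbers. Compound 1 gives 8700 ug/mL, which lies within the scatter of compound 3, so no order can be read between these two. Going by the values given here, compound 2 gives 2000 ug/mL, and the only measured step, a 4.3-fold higher number from compound 2 to compound 3 (0.63 log units; beyond the scatter), is therefore the one that bears on the change at hand.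

Compound 4 `O=C(O)c1cc(-c2c[nH]cn2)ccc1O` has not yet been measured in this assay. It differs from compound 3 by 1H-imidazol-4-yl in place of 1H-pyrrol-1-yl on an aromatic carbon. This change runs the pyrrole-to-imidazole direction of the measured step in reverse, though the imidazole now sits through a carbon rather than a nitrogen and carries a hydrogen-bond donor. On that basis a modest drop is expected, a 2.9-fold lower number from compound 3 to compound 4 (0.46 log units; beyond the scatter), of roughly the size seen between compound 2 and compound 3. Compound 4 is therefore estimated at 3000 ug/mL, with a range from 1200 ug/mL to 8000 ug/mL.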

Compound 4, solubility: 1100 ug/mL
The estimate for compound 4 lay 2.7-fold (0.44 log units) above the measured number; the measured number lies below the stated range.
By their numbers in this assay, from the lowest: compounds 4 and 2 (each within the scatter of the next); then compounds 3 and 1 (each within the scatter of the next).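

In this assay, the position meta to a carboxy group and para to a hydroxy group now shows that the low number is not confined to the imidazole joined through nitrogen. With 1H-imidazol-4-yl in place of 1H-pyrrol-1-yl, the data give a 7.8-fold lower number from compound 3 to compound 4 (0.89 log units; beyond the scatter) in this series. Moving the point of attachment, with 1H-imidazol-4-yl in place of 1H-imidazol-1-yl, gives a 1.8-fold lower number from compound 2 to compound 4 (0.26 log units; within the scatter) and so separates the two imidazoles by no more than the usual scatter; across compound 2, compound 3 and compound 4, the pyrrole stands apart from both imidazoles.

Nothing measured here accounts for these differences. On these data alone, what a simple amine or a methoxy group would give at this same position remains open.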